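Toward a larger anilide substituent on the cyclopropane diamide

The source may hold more compounds than are shown below. What is called first, only, known or untested is meant among the compounds shown, and "the series" means these compounds.

Of the compounds shown here, two sharing one core have been measured in a functional assay on OVCAR-5 cells (Homo sapiens) for inhibition, read by CCK-8 assay, with a stated time of 72 h, tested at 10 uM; a lower number here means less inhibition of growth, a higher number more inhibition of growth at the concentration tested. Compound 1 `CN(C)C(=O)c1cc2cnc(Nc3ccc(NC(=O)C4(C(=O)Nc5ccccc5)CC4)cc3)nc2n1C1CCCC1` gives 77.1% in this assay. Compound 2 `CN(C)C(=O)c1cc2cnc(Nc3ccc(NC(=O)C4(C(=O)Nc5ccccc5F)CC4)cc3)nc2n1C1CCCC1` gives 82.6% in this assay. Among the measured compounds shown here, compound 2 stands highest of the two numbers, but its only neighbour, compound 1, is within the scatter: a number 5.5 percentage points higher from compound 1 to compound 2 (within the scatter).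

Compound 3 `CN(C)C(=O)c1cc2cnc(Nc3ccc(NC(=O)C4(C(=O)Nc5ccc(Cl)c(C(F)(F)F)c5)CC4)cc3)nc2n1C1CCCC1` carries 4-chloro-3-(trifluoromethyl)phenyl in place of 2-fluorophenyl on an amide-type nitrogen. For the measured compounds named here, the one measured step that touches the same anilide ring is the change from compound 1 to compound 2, which stayed within the scatter. Going by the values given here, no measured step introduces chlorine or a trifluoromethyl group on this ring, so the bearing of the new substituents cannot be read from the data; the only guidance is that the one change made here did not move the number beyond the scatter.

Compound 3 is therefore expected to remain close to compound 2, with an estimated 83% and a range from 68% to 94%. This estimate means a step of a number 0.4 percentage points higher from compound 2 to compound 3 (within the scatter), which is expected to stay within the scatter.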

Compound 3, percent growth inhibition at one concentration: 48%
Estimate against measurement, compound 3: 35 percentage points above; measured number outside the range, below it.
By their numbers in this assay, from the lowest: compound 3; then compounds 1 and 2 (each within the scatter of the next).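

In this assay, the group on the amide-type nitrogen proves able to move the number: putting 4-chloro-3-(trifluoromethyl)phenyl in place of 2-fluorophenyl gives a number 34.6 percentage points lower from compound 2 to compound 3 (beyond the scatter), and putting the same group in place of phenyl gives a number 29.1 percentage points lower from compound 1 to compound 3 (beyond the scatter). The earlier fluoro for hydrogen change on this ring had stayed within the scatter, so compound 1 and compound 2 alone gave no sign that this position mattered, whereas compound 3 falls beyond the scatter from both of them. Nothing available explains why this larger substituted ring, with more heavy atoms than the 2-fluorophenyl it replaces, comes with less growth inhibition at the concentration tested.

Chlorine and trifluoromethyl enter together, so the compounds shown leave open whether one of them alone accounts for the drop or whether it takes both, which a phenyl ring carrying only chlorine or only trifluoromethyl would separate. As far as these compounds go, it also remains open how other groups on this ring, such as methyl or methoxy, would compare with the fluoro of compound 2.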